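Methyl on the aromatic ring of compound 1: an expected small step

The source may hold more compounds than are shown below. What is called first, only, known or untested is meant among the compounds shown, and "the series" means these compounds.

Measured compounds, with their values in an assay on SH-SY5Y cells for inhibition of Voltage-dependent L-type calcium channel subunit alpha-1D (Homo sapiens), read by calcium flux, with a stated time of 15 min; a higher number here means a weaker inhibitor, a lower number a stronger inhibitor:
compound 1, `CCOC(=O)C1=C(C)NC(c2ccccc2)=CC1c1ccccc1`, 18700 nM
compound 2, `CCCC1=C(C(=O)OCC)C(c2ccccc2)C=C(c2ccccc2)N1`, 9900 nM
compound 3, `CCOC(=O)C1=C(C)NC(c2ccc(Cl)cc2)=CC1c1ccccc1`, 9300 nM

Compound 1 gives the highest of the three numbers in this assay, but both of its neighbours sit within the scatter: a 1.9-fold lower number from compound 1 to compound 2 (0.28 log units; within the scatter) and a 2.0-fold lower number from compound 1 to compound 3 (0.30 log units; within the scatter). Neither change, the ethyl on the saturated chain carbon nor the chloro on an aromatic carbon, moved the number beyond what repeated measurements would show.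

Compound 4, `CCOC(=O)C1=C(C)NC(c2ccccc2)=CC1c1ccc(C)cc1`, differs from compound 1 by methyl in place of hydrogen on an aromatic carbon. The step from compound 1 to compound 3 is the closest relative, a substituent entering an aromatic carbon, and it stayed within the scatter; the step to compound 2 did likewise. From this the author expects no step beyond the scatter for compound 4, at most a shift of the size seen so far, a 1.4-fold lower number from compound 1 to compound 4 (0.16 log units; within the scatter). Compound 4 is therefore estimated at 13000 nM in this assay, with a range of 5000 nM to 35000 nM.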

Compound 4, half-maximal inhibitory concentration: 20600 nM
The estimate for compound 4 lay 1.6-fold (0.20 log units) below the measured number; the range from low to high includes it.
By their numbers in this assay, from the lowest: compounds 3, 2, 1 and 4 (each within the scatter of the next, the first and the last beyond it).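

Phenyl to 4-methylphenyl gives a 1.1-fold higher number from compound 1 to compound 4 (0.04 log units; within the scatter) in this assay. This is the first change shown on the aromatic ring that carries the methyl, since the steps to compound 2 and compound 3 changed other places in the core of compound 1, and it shows that one added carbon on an aromatic carbon para to a large group leaves the number within the scatter. Nothing shown explains why this step is so small.

The compounds shown leave open whether a larger or differently built group in the same place, such as a carboxylic acid, an amine or a longer chain, would move the number beyond the scatter. They also leave open whether methyl on another carbon of this ring would behave as it does here.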